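The source may report more compounds than this note shows. Statements on the series, on what has been measured and on what is new or still open speak of the compounds shown alone.

In a functional assay on THP-1 cells (Homo sapiens) for inhibition, read by sulforhodamine B assay, with a stated time of 48 h, tested at 50 uM (a lower number here means less inhibition of growth, a higher number more inhibition of growth at the concentration tested), compound 1 (`COc1cccc(/C=C/C(=O)/C=C/c2ccc(OCc3cn(CCCOc4cc(=O)oc5ccccc45)nn3)c(OC)c2)c1`) gives 58% and stands highest of the two numbers measured, while compound 2 (`COc1ccccc1/C=C/C(=O)/C=C/c1ccc(OCc2cn(CCCCOc3cc(=O)oc4ccccc34)nn2)c(OC)c1`) gives 40% as a number lower beyond the usual scatter. Compound 3 (`COc1cc(/C=C/C(=O)/C=C/c2cccs2)ccc1OCc1cn(CCCOc2cc(=O)oc3ccccc23)nn1`) differs from compound 1 in one place (thiophen-2-yl in place of 3-methoxyphenyl on a double-bonded chain carbon bound to a double-bonded chain carbon), with thiophen-2-yl in place of 3-methoxyphenyl on a double-bonded chain carbon bound to a double-bonded chain carbon. For the measured compounds named here, no measured pair shows this change, so only a modest fall in this assay is expected, possibly none beyond the scatter. The expected size is a number 8 percentage points lower from compound 1 to compound 3 (within the scatter) as an estimate. Compound 3 is estimated at 50% with an expected range from 30% to 70% in this measurement.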

Compound 3, percent growth inhibition at one concentration: 54%
Beside the measured number, compound 3's estimate is 4 percentage points below it; the range from low to high includes it.
By their numbers in this assay, from the lowest: compound 2; then compounds 3 and 1 (each within the scatter of the next).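

In this assay, placing thiophen-2-yl in place of 3-methoxyphenyl gives a number 4 percentage points lower from compound 1 to compound 3 (within the scatter). This position on a double-bonded chain carbon bound to a double-bonded chain carbon therefore accepts a five-membered aromatic ring holding sulfur as well as a methoxy-bearing six-membered ring of carbon only, with no change beyond the scatter. Nothing offered here explains this result.

The compounds shown leave open whether pyridin-3-yl, or a phenyl ring carrying a carboxylic acid or a dimethylamino group, would be accepted at this position. This single step also cannot say whether the exchange would read the same with a longer chain on the triazole.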